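The source may hold more compounds than are shown below. What is called first, only, known or untested is meant among the compounds shown, and "the series" means these compounds.

In an in vitro functional assay on HEK285-7 cells for antagonist activity at prostaglandin D2 receptor 2 (Homo sapiens), read by BRET and beta-arrestin recruitment (a higher number here means a weaker inhibitor, a lower number a stronger inhibitor), compound 1 `Nc1nc(-c2ccc(Cl)cc2)c(CC(=O)O)s1` gives a value recorded only as a limit, > 100000 nM, the limit noted in the limit of > 100000 nM in this assay, at which 1 of the 3 values shown sits. Compound 2 `O=C(O)Cc1sc(C(Cc2ccccc2)c2ccccc2)nc1-c1ccc(Cl)cc1` gives 510 nM, and compound 3 `O=C(O)Cc1sc(C(c2ccc(F)cc2)c2ccc(F)cc2)nc1-c1ccc(Cl)cc1` gives 180 nM, the lowest of the two numbers, with compound 2 beyond the scatter above it. Compound 4 `O=C(O)Cc1sc(C(c2ccc(F)cc2)c2ccc(F)cc2)nc1-c1ccnc(Cl)c1` differs from compound 3 in one place: 2-chloropyridin-4-yl in place of 4-chlorophenyl on an aromatic carbon. No measured step of this kind exists among these compounds, so the expectation rests on the numbers of compound 3 alone; a small step toward a weaker value, still within the usual scatter, is expected, a 1.7-fold higher number from compound 3 to compound 4 (0.22 log units; within the scatter). Compound 4 is therefore estimated at 300 nM in this assay, with a likely range from 100 nM to 1000 nM.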

Compound 4, half-maximal inhibitory concentration: 39 nM
Compound 4: the middle estimate sits 7.7-fold (0.89 log units) above what was measured; the whole stated range lies above it.
By their numbers in this assay, from the lowest: compound 4; then compound 3; then compound 2. At a limit, above all of these: compound 1.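

The change to 2-chloropyridin-4-yl on this aromatic carbon gives in this assay a 4.6-fold lower number from compound 3 to compound 4 (0.66 log units; beyond the scatter) and so the position takes a ring nitrogen, and with it a hydrogen-bond acceptor, with a gain rather than a loss. This is the first change shown at this position, and it is a single step. Nothing measured here accounts for the gain.

From the compounds shown here alone, whether the chlorine is needed remains open, as does whether a methoxy group or a nitrile in its place would keep the gain. Going by these compounds, it also remains open whether the gain carries over to compound 2, with its different large group.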